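Clearance notes: 1-ethyl-1H-pyrazol-4-yl to 1-ethyl-5-methyl-1H-pyrazol-4-yl

The source may hold more compounds than are shown below. What is called first, only, known or untested is meant among the compounds shown, and "the series" means these compounds.

For the measured compounds named here, in an ADME assay (liver) for metabolic stability, with Liver microsome (Homo sapiens) as the target, read by LC-MS, using microsomes and NADPH, with a stated time of 5 min, at 37 degrees C (on this read-out higher numbers stand for fast clearance and lower numbers for slow clearance), compound 3 (`CCn1cc(S(=O)(=O)N[C@H](C)c2nc3ccc(C(F)(F)F)cc3n2CC)cn1`) gives 95 mL.min-1.g-1 as the only true number in the set. Compound 1 (`CCn1c([C@@H](C)NS(=O)(=O)c2cccc(Cl)c2)nc2ccc(C(F)(F)F)cc21`) reads > 100 mL.min-1.g-1 as a limit of the assay. Compound 2 (`CCn1c([C@@H](C)NS(=O)(=O)c2ccccn2)nc2ccc(C(F)(F)F)cc21`) reads < 3 mL.min-1.g-1 as a limit of the assay too. Compound 3 therefore sits with compound 1 at the fast-clearance end.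

Compound 4 (`CCn1ncc(S(=O)(=O)N[C@H](C)c2nc3ccc(C(F)(F)F)cc3n2CC)c1C`) carries methyl in place of hydrogen on an aromatic carbon, turning 1-ethyl-1H-pyrazol-4-yl into 1-ethyl-5-methyl-1H-pyrazol-4-yl.

Going by the values given here, three measured steps bear on this, all changing the group on the sulfonyl sulfur and none adding a methyl: an at least 33-fold lower number from compound 1 to compound 2 (1.52 log units; beyond the scatter) and an at least 31-fold higher number from compound 2 to compound 3 (1.50 log units; beyond the scatter) are large, whereas an at least 1.0-fold lower number from compound 1 to compound 3 (0.02 log units; that floor lies within the scatter) stays within the scatter. The last is the closest guide, so no change beyond the scatter is expected in this assay, and the estimated step is a 1.1-fold lower number from compound 3 to compound 4 (0.02 log units; within the scatter) in either direction. The expected value for compound 4 is 90 mL.min-1.g-1 in this assay, with an estimated range of 40 mL.min-1.g-1 to 160 mL.min-1.g-1 for the measurement.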

Compound 4, intrinsic clearance in microsomes: > 100 mL.min-1.g-1
Compound 4 ended at the assay's limit (the forecaster's own chance of this, stated with the estimate: 30%); at least 1.1-fold (0.04 log units) between middle value and limit.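

In this assay compound 4 reads > 100 mL.min-1.g-1, which is a limit of the assay. Methyl in place of hydrogen on this aromatic carbon, next to the ring atom that bears an ethyl group, gives an at least 1.0-fold higher number from compound 3 to compound 4 (0.02 log units; that floor lies within the scatter), so this change does not move the series toward slow clearance, though the floor of the step lies within the scatter. The 1-ethyl-5-methyl-1H-pyrazol-4-yl group stays far from pyridin-2-yl, with an at least 33-fold higher number from compound 2 to compound 4 (1.52 log units; beyond the scatter), while the step between compound 1 and compound 4 cannot be read, as both rest on one limit: the limit of > 100 mL.min-1.g-1 in this assay, at which 2 of the 4 values shown sit.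

How far compound 4 lies past its limit stays unknown, so a real rise in clearance with the methyl can be neither shown nor excluded. On these data alone, what a hydroxymethyl or an amine on this aromatic carbon would give in this assay remains open.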